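Methoxy to Chloro at the Para Position: Expected Effect

The compounds below may be only part of what the source reports. "The series", "measured", "known", "first", "only" and "open" are said of these compounds alone.

Measured compounds:
Compound 1, `Fc1ccc(-c2csc(N/N=C/c3ccc(Cl)cc3Cl)n2)cc1`: 90%
Compound 2, `COc1ccc(-c2csc(N/N=C/c3ccc(Cl)cc3Cl)n2)cc1`: 79.7%

In a functional assay, read by spectrophotometry, with a stated time of 15 min, tested at 40 ug/mL (on this read-out lower numbers stand for a weaker effect and higher numbers for a stronger effect at the one concentration tested), compound 2 stands lowest of the two numbers; the step of a number 10.3 percentage points lower from compound 1 to compound 2 (beyond the scatter) lies beyond the scatter. Compound 3, `Clc1ccc(-c2csc(N/N=C/c3ccc(Cl)cc3Cl)n2)cc1`, differs from compound 2 by chloro in place of methoxy on an aromatic carbon. Within the data shown here, the only measured step that bears on this, a number 10.3 percentage points lower from compound 1 to compound 2 (beyond the scatter), replaced a fluoro by methoxy; here the methoxy gives way to another halogen, chloro. Compound 3 is therefore expected to move back upward by a modest step, a number 6.3 percentage points higher from compound 2 to compound 3 (within the scatter). The estimate for compound 3 is 86%, within 74% to 95%.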

Compound 3, a percentage reported as inhibition, at one concentration (the size of the read-out at that concentration, not a potency): 76.2%
Estimate against measurement, compound 3: 9.8 percentage points above; low and high end bracket the measured number.
By their numbers in this assay, from the lowest: compounds 3 and 2 (each within the scatter of the next); then compound 1.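

In this assay, putting chloro in place of methoxy at this position brings no recovery, with a number 3.5 percentage points lower from compound 2 to compound 3 (within the scatter). The gap to the fluoro compound remains, at a number 13.8 percentage points lower from compound 1 to compound 3 (beyond the scatter), so among these three compounds a halogen alone does not give the higher number: compound 1 stands apart, and compound 3 goes against any halogen pattern. Nothing available explains why fluoro and chloro differ here.

On these data alone, whether a plain hydrogen, an amine or a carboxylic acid at this position would fall with compound 1 or with compound 2 and compound 3 remains open.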